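Toward Compound 4: Nitro and Chloro Changes in Cytotoxicity

The source may report more compounds than this note shows. Statements on the series, on what has been measured and on what is new or still open speak of the compounds shown alone.

Compound 1 `Cc1ccccc1C(=O)N(C(=S)OCCN1C(=O)c2ccccc2C1=O)c1ccc(Cl)cc1`: 21000 nM
Compound 2 `O=C1c2ccccc2C(=O)N1CCOC(=S)N(C(=O)c1ccccc1[N+](=O)[O-])c1ccc(Cl)cc1`: 21000 nM
Compound 3 `O=C1c2ccccc2C(=O)N1CCOC(=S)N(C(=O)c1ccc([N+](=O)[O-])cc1)c1ccc(Cl)cc1`: > 100000 nM

In an ADME assay on MT4 cells (Homo sapiens) for cytotoxicity, read by MTT assay (on this read-out higher numbers stand for lower toxicity in this test and lower numbers for higher toxicity in this test), compound 1 stands level with compound 2, as no change at the digits printed from compound 1 to compound 2 (within the scatter) shows. For compound 3 the value is a limit of the assay, not a number, (the limit of > 100000 nM in this assay, at which 1 of the 3 values shown sits). Compound 4 `O=C1c2ccccc2C(=O)N1CCOC(=S)N(C(=O)c1ccc([N+](=O)[O-])cc1Cl)c1ccc(Cl)cc1` differs from compound 1 by 2-chloro-4-nitrophenyl in place of 2-methylphenyl on a carbonyl carbon. The measured steps that bear on this both place a 4-nitrophenyl on that carbonyl carbon: an at least 4.7-fold higher number from compound 1 to compound 3 (0.67 log units; beyond the scatter) and an at least 4.7-fold higher number from compound 2 to compound 3 (0.67 log units; beyond the scatter). Compound 4 carries a 2-chloro-4-nitrophenyl there, so a clearly higher number, probably again reaching the limit, is expected: a 4.8-fold higher number from compound 1 to compound 4 (0.68 log units; beyond the scatter). Compound 4 is estimated at 100000 nM, ranging from 40000 nM to 250000 nM.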

Compound 4, half-maximal cytotoxic concentration: 19000 nM
Beside the measured number, compound 4's estimate is 5.3-fold (0.72 log units) above it; the whole stated range lies above it.
By their numbers in this assay, from the lowest: compounds 4, 1 and 2 (each within the scatter of the next). At a limit, above all of these: compound 3.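

In this assay a single chloro in place of hydrogen on an aromatic carbon is enough to bring the number down, with an at least 5.2-fold lower number from compound 3 to compound 4 (0.72 log units; beyond the scatter). The 2-chloro-4-nitrophenyl group on this carbonyl carbon therefore stands level with 2-methylphenyl and 2-nitrophenyl, with a 1.1-fold lower number from compound 1 to compound 4 (0.04 log units; within the scatter) and with a 1.1-fold lower number from compound 2 to compound 4 (0.04 log units; within the scatter). The value of compound 3, where the first of these steps starts, is a limit and not a number: the limit of > 100000 nM in this assay, at which 1 of the 4 values shown sits.

From the compounds shown here alone, whether a group other than chloro on that ring, such as an amine or a methoxy group, would also lower the number stays open.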